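The compounds below may be only part of what the source reports. "The series", "measured", "known", "first", "only" and "open" are said of these compounds alone.

Measured compounds in a functional assay on PC-3 cells (Homo sapiens) for cytotoxicity, read by MTT assay, with a stated time of 72 h; on this read-out higher numbers stand for weaker inhibition and lower numbers for stronger inhibition:
compound 1, `Cc1cc(=O)n(-c2cccc(F)c2)nc1C(=O)Nc1ccc(Oc2ncnc3[nH]ccc23)cc1`; compound 1 gives 14600 nM
compound 2, `Cc1cc(=O)n(-c2ccccc2OC(F)(F)F)nc1C(=O)Nc1ccc(Oc2ncnc3c2ccn3C)cc1`; compound 2 gives 5160 nM
compound 3, `Cc1cc(=O)n(-c2cccc(F)c2)nc1C(=O)Nc1ccc(Oc2ncnc3c2ccn3C)cc1`; for compound 3 only a limit is recorded, > 60000 nM

Among the compounds with values here, compound 3 thus stands at the limit of this assay, the one value of the three that sits at the limit of > 60000 nM in this assay, at which 1 of the 3 values shown sits, and its true number is not known. The step to compound 4, `Cc1cc(=O)n(-c2ccccc2C(F)(F)F)nc1C(=O)Nc1ccc(Oc2ncnc3c2ccn3C)cc1`, is 2-(trifluoromethyl)phenyl in place of 3-fluorophenyl on an aromatic nitrogen. Within the data shown here, two measured steps bear on it. an at least 4.1-fold higher number from compound 1 to compound 3 (0.61 log units; beyond the scatter) concerns the methyl on the aromatic nitrogen, which compound 4 shares with compound 3, so it does not separate the two. an at least 11-fold higher number from compound 2 to compound 3 (1.06 log units; beyond the scatter) is the closer guide: compound 2 carries a 2-(trifluoromethoxy)phenyl and compound 4 a 2-(trifluoromethyl)phenyl on the same nitrogen, so the change to compound 4 is expected to run back in the direction of compound 2, an estimated step of an at least 8.5-fold lower number from compound 3 to compound 4 (0.93 log units; beyond the scatter) in this assay. Compound 4 is therefore expected at 7000 nM, within 2500 nM to 30000 nM. Compound 3 is known only as a limit; the size of the expected step carries that uncertainty.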

Compound 4, half-maximal inhibitory concentration: 19100 nM
Estimate against measurement, compound 4: 2.7-fold (0.44 log units) below; the measured number falls inside the stated range.
By their numbers in this assay, from the lowest: compound 2; then compounds 1 and 4 (each within the scatter of the next). At a limit, above all of these: compound 3.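

In this assay, 2-(trifluoromethyl)phenyl in place of 3-fluorophenyl on the aromatic nitrogen gives an at least 3.1-fold lower number from compound 3 to compound 4 (0.49 log units; beyond the scatter), so a second group at this position returns a measurable number. Compound 3 is recorded only as a limit, so the size of that step is a floor: the limit of > 60000 nM in this assay, at which 1 of the 4 values shown sits. The two groups at this position are also not interchangeable, as trifluoromethyl in place of trifluoromethoxy gives a 3.7-fold higher number from compound 2 to compound 4 (0.57 log units; beyond the scatter).

Going by these compounds, it remains open whether the change from compound 3 to compound 4 follows the place of the substituent on the phenyl ring or the substituent itself; a 2-fluorophenyl or a 3-(trifluoromethyl)phenyl on the same nitrogen would separate the two. Also open, on these data alone, is how a group of another kind, such as 2-aminophenyl, would read at this position.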